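A few compounds are considered here, and "the series" means these few. Any claim that something is new, unique, unknown or untested is made for them only; others in the source may bear on it.

Measured compounds:
- compound 1 `COc1ccc(C)c(N2CCC(COc3cccc(C(CC(=O)O)C4CC4)c3)CC2)c1`, in a functional assay on cells for agonist activity at Free fatty acid receptor 1 (Homo sapiens), read by FLIPR and calcium flux, with a stated time of 60 min (a higher number here means that more compound is needed for the effect, a lower number that less compound is needed), compound 1 gives 270 nM
- compound 2 `COc1ccc(CCC(C)(C)C)c(N2CCC(COc3cccc(C(CC(=O)O)C4CC4)c3)CC2)c1`, compound 2 gives 34 nM
- compound 3 `COc1ccc(CCC(C)(C)O)c(N2CCC(COc3cccc(C(CC(=O)O)C4CC4)c3)CC2)c1`, compound 3 gives 970 nM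

Compound 3 stands highest of the three numbers in this assay: compound 1 sits nearest, compound 2 furthest. The measured steps are a 7.9-fold lower number from compound 1 to compound 2 (0.90 log units; beyond the scatter), a 3.6-fold higher number from compound 1 to compound 3 (0.56 log units; beyond the scatter) and a 29-fold higher number from compound 2 to compound 3 (1.46 log units; beyond the scatter); the last is the large one, the first two are modest.

Compound 4 `COc1ccc(CN(C)CC(C)C)c(N2CCC(COc3cccc(C(CC(=O)O)C4CC4)c3)CC2)c1` is not yet measured. It differs from compound 3 by isobutyl(methyl)amino in place of 2-hydroxy-2-methylpropyl on a saturated chain carbon bound to an aromatic carbon, so the group with the hydrogen-bond donor leaves and a group with none enters. The step from compound 2 to compound 3 bears most directly on this: a hydroxy entering in place of a methyl on the chain raised the number sharply, and the present change reverses the presence of that donor while keeping a branched chain of comparable size. The step from compound 1 to compound 2 suggests a branched chain in this place lowers the number. A lower number is therefore expected for compound 4 in this assay, of roughly a 9.7-fold lower number from compound 3 to compound 4 (0.99 log units; beyond the scatter), placing it between compound 1 and compound 2. The estimate for compound 4 is 100 nM, with a range from 25 nM to 400 nM.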

Compound 4, half-maximal effective concentration: 1000 nM
For compound 4 the middle estimate is 10-fold (1.00 log units) below the measured one, outside the stated range (above it).
By their numbers in this assay, from the lowest: compound 2; then compound 1; then compounds 3 and 4 (each within the scatter of the next).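

In this assay, the absence of a hydrogen-bond donor does not by itself restore the low number of compound 2: with isobutyl(methyl)amino, which has 0 hydrogen-bond donors, in place of 2-hydroxy-2-methylpropyl, the data show a 1.0-fold higher number from compound 3 to compound 4 (0.01 log units; within the scatter). The lowering seen with neopentyl on a saturated chain carbon bound to an aromatic carbon also does not extend to this branched amine, as shown by a 29-fold higher number from compound 2 to compound 4 (1.47 log units; beyond the scatter) and, against hydrogen, a 3.7-fold higher number from compound 1 to compound 4 (0.57 log units; beyond the scatter). No measurement at hand explains this result.

The compounds shown do not separate the contribution of the amine nitrogen from that of the arrangement of the chain. Also open, as far as these compounds go, is whether an ether in place of the amine, or a longer unbranched alkyl chain, would give a number near that of compound 2 or nearer those of compounds 3 and 4.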